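Swapping the aryl ketone on a pyrazole chalcone scaffold

This account rests on a few compounds, and the source may have more. Where it says the series, first, only, none or still open, it means among the compounds named here.

Measured compounds:
- compound 1, `COc1ccc(-c2cc(/C=C/C(=O)c3ccc(OC)c(OC)c3)[nH]n2)cc1`: 96%
- compound 2, `COc1cc(-c2cc(/C=C/C(=O)c3ccc(Cl)c(Cl)c3)[nH]n2)cc(OC)c1OC`: 91%
- compound 3, `COc1ccc(-c2cc(/C=C/C(=O)c3ccc(N)cc3)[nH]n2)cc1`: 97%

In a functional assay on CAKI-1 cells (Homo sapiens) for cytotoxicity, read by sulforhodamine B assay, with a stated time of 48 h, tested at 0.1 uM (a lower number here means a stronger effect, a higher number a weaker effect of the compound at the concentration tested), compound 1 gives 96%. In this assay compound 2 gives 91%, and in this assay compound 3 gives 97%. Compound 2 has the lowest of the three numbers, but its distance to compound 1 and to compound 3 is within the usual scatter, so the three read as alike: all three leave the cells close to untouched at this concentration.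

Compound 4, `COc1ccc(C(=O)/C=C/c2cc(-c3cc(OC)c(OC)c(OC)c3)n[nH]2)cc1`, has not yet been measured. It keeps the shared core of compound 2 and differs from it in one place: 4-methoxyphenyl in place of 3,4-dichlorophenyl on a carbonyl carbon. Among the compounds with values here, no directly measured pair of compounds that differ in one place is available, so the size of this step has to be judged from the three values alone.

Those three values cluster at the weak end regardless of which aryl group sits on the carbonyl carbon. Compound 4 is therefore expected to give about 95% in this assay, within 85% to 102%. The expected step of a number 4 percentage points higher from compound 2 to compound 4 (within the scatter) is estimated to lie within the scatter, in no clear direction.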

Compound 4, a percentage reported as activity, at one concentration (the size of the read-out at that concentration, not a potency): 93%
Compound 4: middle estimate off by 2 percentage points, on the high side; the range from low to high includes it.
By their numbers in this assay, from the lowest: compounds 2, 4, 1 and 3 (each within the scatter of the next).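

Within the data shown here, the pair of compound 2 and compound 4 is the first comparison here that isolates a single place on the shared core. In this assay, putting 4-methoxyphenyl in place of 3,4-dichlorophenyl on a carbonyl carbon gives a number 2 percentage points higher from compound 2 to compound 4 (within the scatter), so this exchange does not separate the two compounds at the concentration tested. Losing both chlorines and gaining one hydrogen-bond acceptor, with the heavy-atom count unchanged at 8, therefore leaves the read-out where it was, and nothing available explains why this position shows no response.

Compound 2 and compound 4 both leave the cells close to untouched at this one concentration, so any difference between these two aryl groups that might appear at higher concentrations cannot be seen from these numbers. Also open, on these data alone, is whether a phenyl ring carrying a carboxylic acid, or a plain alkyl chain, on the same carbonyl carbon would bring the number down from this weak range.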